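Swapping the Acid Tail for a Tetrazole Amide

The source may report more compounds than this note shows. Statements on the series, on what has been measured and on what is new or still open speak of the compounds shown alone.

Compound 1 `CCc1cc(C(C)=O)c(O)cc1OCCCCC#N`: 92%
Compound 2 `CCc1cc(C(C)=O)c(O)cc1OCCCC(C)(C)C(=O)O`: 89%
Compound 3 `CCc1cc(C(C)=O)c(O)cc1OCCCCCC(C)(C)C(=O)O`: 104%

In an assay on isolated protein for inhibition of leukotriene B4 receptor 1 (Homo sapiens), tested at 10 uM (a lower number here means less inhibition, a higher number more inhibition at the concentration tested (going by the name of the read-out)), compound 3 stands highest of the three numbers, separated from the others by a number 12 percentage points higher from compound 1 to compound 3 (beyond the scatter) and a number 15 percentage points higher from compound 2 to compound 3 (beyond the scatter). Compound 4 `CCc1cc(C(C)=O)c(O)cc1OCCCCCCC(=O)Nc1nn[nH]n1` is the next variation: ((2H-tetrazol-5-yl)carbamoyl)methyl in place of 1-carboxy-1-methylethyl on a saturated chain carbon, five bonds along the chain from an oxygen on an aromatic ring. For the measured compounds named here, no measured step replaces the acid with a tetrazole amide; the only step touching the acid itself, a number 3 percentage points lower from compound 1 to compound 2 (within the scatter), exchanged it for a nitrile and stayed within the scatter, while the chain-lengthening steps shifted the number only modestly. For compound 4 the expected change is therefore a number 12 percentage points lower from compound 3 to compound 4 (beyond the scatter), a small shift that may not exceed the scatter. Compound 4 is estimated to give 92%, within a range from 72% to 106%.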

Compound 4, a percentage reported as inhibition, at one concentration (the size of the read-out at that concentration, not a potency): 101%
Compound 4: middle estimate off by 9 percentage points, on the low side; measured number inside the range.
By their numbers in this assay, from the lowest: compounds 2, 1, 4 and 3 (each within the scatter of the next, the first and the last beyond it).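

In this assay, ((2H-tetrazol-5-yl)carbamoyl)methyl replaces 1-carboxy-1-methylethyl with a number 3 percentage points lower from compound 3 to compound 4 (within the scatter), so this position holds a tetrazole amide as well as it holds a carboxylic acid. The earlier compounds shown here carried only open-chain ends here, whereas this group brings a five-membered aromatic ring. Nothing available explains this result.
A single concentration also says nothing about potency, so compound 3 and compound 4 may still differ at lower concentrations. The compounds shown leave open whether a tetrazole joined directly to the chain, without the amide, or a plain primary amide would fit here too.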